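Nitro for methoxy: an estimate for compound 4

This account rests on a few compounds, and the source may have more. Where it says the series, first, only, none or still open, it means among the compounds named here.

Of the compounds shown here, three have been measured in a functional assay on HepG2 cells (Homo sapiens) for antiproliferative activity, read by MTT assay, with a stated time of 48 h; on this read-out lower numbers stand for stronger inhibition and higher numbers for weaker inhibition.
Compound 1 `Cc1ccc(N2CCN(Cn3nc(-c4ccc5c(c4)OCCO5)oc3=S)CC2)c(C)c1` gives 28400 nM.
Compound 2 `COc1cccc(N2CCN(Cn3nc(-c4ccc5c(c4)OCCO5)oc3=S)CC2)c1` gives 21400 nM.
Compound 3 `COc1ccc(N2CCN(Cn3nc(-c4ccc5c(c4)OCCO5)oc3=S)CC2)cc1` gives only a limit of the assay, > 50000 nM.

Compound 3 therefore stands without a firm number; its result is the one that sits at the limit of > 50000 nM in this assay, at which 1 of the 3 values shown sits. The steps toward it read an at least 1.7-fold higher number from compound 1 to compound 3 (0.24 log units; that floor lies within the scatter) and an at least 2.3-fold higher number from compound 2 to compound 3 (0.36 log units; beyond the scatter), whereas a 1.3-fold lower number from compound 1 to compound 2 (0.12 log units; within the scatter).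

Compound 4 `O=[N+]([O-])c1ccc(N2CCN(Cn3nc(-c4ccc5c(c4)OCCO5)oc3=S)CC2)cc1` differs from compound 3 by nitro in place of methoxy on an aromatic carbon. Going by the values given here, none of the measured steps exchanges methoxy for nitro; all three concern methyl and methoxy groups and where they sit on the same six-membered aromatic ring of carbon only. They bear on the present step only by placing compound 3 at the limit of this assay, so no step beyond the scatter can be expected in either direction, and a further limit is about as likely as a number. Compound 4 is accordingly estimated at 45000 nM, with a range from 15000 nM to 100000 nM. The expected change is an at least 1.1-fold lower number from compound 3 to compound 4 (0.04 log units; that floor lies within the scatter).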

Compound 4, half-maximal inhibitory concentration: 29500 nM
For compound 4 the middle estimate is 1.5-fold (0.18 log units) above the measured one; low and high end bracket the measured number.
By their numbers in this assay, from the lowest: compounds 2, 1 and 4 (each within the scatter of the next). At a limit, above all of these: compound 3.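

In this assay compound 3 gives only a limit of the assay, > 50000 nM, whereas 4-nitrophenyl in place of 4-methoxyphenyl gives compound 4 a firm number. The exchange of methoxy for nitro reads an at least 1.6-fold lower number from compound 3 to compound 4 (0.22 log units; that floor lies within the scatter), and its size remains a floor because one end of the step is not a number: the limit of > 50000 nM in this assay, at which 1 of the 4 values shown sits. The steps of a 1.4-fold higher number from compound 2 to compound 4 (0.14 log units; within the scatter) and a 1.0-fold higher number from compound 1 to compound 4 (0.02 log units; within the scatter) both lie within the scatter, so the limit does not hold for every group on this aromatic carbon.

From the compounds shown here alone, how far the true step from methoxy to nitro exceeds its floor stays open. The compounds shown also leave open whether an amine or a carboxylic acid on this aromatic carbon would give a number or a limit.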